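This account rests on a few compounds, and the source may have more. Where it says the series, first, only, none or still open, it means among the compounds named here.

Compound 1 `CC(C)=CCOc1cccc(O)c1C(=O)/C=C/c1ccc(O)cc1`: in a functional assay on NUGC-3 cells (Homo sapiens) for antiproliferative activity, read by sulforhodamine B assay (a lower number here means a stronger inhibitor of growth, a higher number a weaker inhibitor of growth), compound 1 gives > 30000 nM, which is a limit of the assay and not a number.
Compound 2 `O=C(/C=C/c1ccc(O)cc1)c1c(O)cccc1OCc1ccccc1`: compound 2 gives > 30000 nM, again only a limit.
Compound 3 `CC(C)(C)CCOc1cccc(O)c1C(=O)/C=C/c1ccc(O)cc1`: compound 3 gives 3300 nM.

Compound 1 thus stands at the upper limit of what this assay reports (the limit of > 30000 nM in this assay, at which 2 of the 3 values shown sit). Compound 4 `CC(C)CCOc1cccc(O)c1C(=O)/C=C/c1ccc(O)cc1` differs from compound 1 by isobutyl in place of 2-methylprop-1-en-1-yl on a saturated chain carbon bound to an oxygen on an aromatic ring. The step that bears on this change is an at least 9.0-fold lower number from compound 1 to compound 3 (0.95 log units; beyond the scatter), where a neopentyl group without the double bond entered; the step that the two limits leave unreadable from compound 1 to compound 2 cannot be read. A lower number is therefore expected for compound 4, but isobutyl is not neopentyl, so the expected step of an at least 2.5-fold lower number from compound 1 to compound 4 (0.39 log units; beyond the scatter) is taken as smaller. Compound 4 is estimated at 12000 nM, within 3000 nM to 30000 nM.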

Compound 4, concentration for 50% growth inhibition: 12400 nM
Compound 4: the middle estimate sits 1.0-fold (0.01 log units) below what was measured; the range from low to high includes it.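

With the double bond gone and the carbon count unchanged, this assay shows an at least 2.4-fold lower number from compound 1 to compound 4 (0.38 log units; beyond the scatter). A single methyl group matters as well: removing it gives a 3.8-fold higher number from compound 3 to compound 4 (0.57 log units; beyond the scatter), so losing the double bond does not account for the whole gain seen with neopentyl. The saturated isobutyl group also compares well with phenyl, giving an at least 2.4-fold lower number from compound 2 to compound 4 (0.38 log units; beyond the scatter).

The compounds shown leave open whether a longer saturated chain, such as hexyl, would lower the number further. They also leave open how cyclohexyl would compare with phenyl in this place.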